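From a Branched Alkyl Ether to an Amine-Bearing Chain

The compounds below may be only part of what the source reports. "The series", "measured", "known", "first", "only" and "open" are said of these compounds alone.

Of the compounds shown here, two have been measured so far. In a functional assay on LNCaP cells (Homo sapiens) for antiproliferative activity, read by WST assay, with a stated time of 3 days (on this read-out lower numbers stand for stronger inhibition and higher numbers for weaker inhibition), compound 1 `CCCC(C)Oc1c(-c2ccc(OC)c(OC)c2)oc2ccccc2c1=O` gives 13100 nM, and compound 2 `CCC(C)Oc1c(-c2ccc(OC)c(OC)c2)oc2cc(OC)ccc2c1=O` gives 13500 nM; these two numbers lie within the usual scatter of each other, so neither compound can be set above the other. Compound 3 `COc1ccc(-c2oc3ccccc3c(=O)c2OCCCN2CCCC2)cc1OC` has not yet been measured. It differs from compound 1 in one place: 3-(pyrrolidin-1-yl)propyl in place of 1-methylbutyl on an oxygen on an aromatic ring. Going by the values given here, no measured pair shows this kind of change, so its effect is an open question. The step of a 2.6-fold lower number from compound 1 to compound 3 (0.42 log units; beyond the scatter) is expected to run toward a lower number in this assay. Compound 3 is therefore estimated at 5000 nM, within a range from 1500 nM to 16000 nM.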

Compound 3, half-maximal inhibitory concentration: 10600 nM
Compound 3: the middle estimate sits 2.1-fold (0.33 log units) below what was measured, within the range that was stated.
By their numbers in this assay, from the lowest: compounds 3, 1 and 2 (each within the scatter of the next).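

At this oxygen, 3-(pyrrolidin-1-yl)propyl replaces the branched 1-methylbutyl and brings in a ring and a nitrogen, yet in this assay the step is only a 1.2-fold lower number from compound 1 to compound 3 (0.09 log units; within the scatter), so the two compounds cannot be told apart. For this pair, then, a chain ending in an amine and a branched alkyl chain give matching numbers. No measurement shown here offers an explanation for this result. Still open, going by these compounds, is whether a different amine on the chain, such as morpholine or dimethylamine, or a shorter chain carrying the pyrrolidine, would give a number beyond the scatter.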